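Swapping the para substituent on a bis-benzylidene cyclohexanone

This account rests on a few compounds, and the source may have more. Where it says the series, first, only, none or still open, it means among the compounds named here.

Measured so far:
- compound 1 `O=C1/C(=C/c2ccccc2)CCC/C1=C\c1cccc([N+](=O)[O-])c1`: 9440 nM
- compound 2 `O=C1/C(=C/c2ccc(Cl)cc2)CCC/C1=C\c1cccc([N+](=O)[O-])c1`: 9160 nM
- compound 3 `CN(C)c1ccc(/C=C2\CCC/C(=C\c3cccc([N+](=O)[O-])c3)C2=O)cc1`: 156000 nM

All three share one core: a cyclohexanone carrying two benzylidene arms, one of them bearing a nitro group. They were tested in a functional assay on L1210 cells (Mus musculus) for cytotoxicity, with a stated time of 48 h; on this read-out lower numbers stand for stronger inhibition and higher numbers for weaker inhibition. Compound 3 gives the highest number of the three, so it is the weakest inhibitor in this set; its steps to compound 1 and to compound 2 both lie beyond the scatter.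

Compound 4 `COc1ccc(/C=C2\CCC/C(=C\c3cccc([N+](=O)[O-])c3)C2=O)cc1` differs from compound 3 in one place: methoxy in place of dimethylamino on an aromatic carbon. Going by the values given here, no measured step makes exactly this exchange. The two that come closest both remove the dimethylamino group, replacing it with hydrogen in a 17-fold higher number from compound 1 to compound 3 (1.22 log units; beyond the scatter) read backwards and with chloro in a 17-fold higher number from compound 2 to compound 3 (1.23 log units; beyond the scatter) read backwards, and each was large. A methoxy group is neither hydrogen nor chloro, so the change from compound 3 to compound 4 is expected to give a clearly lower number, though perhaps not all the way back to compound 1, a step estimated at a 5.2-fold lower number from compound 3 to compound 4 (0.72 log units; beyond the scatter). Compound 4 is therefore estimated at 30000 nM in this assay, within a range from 8000 nM to 120000 nM.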

Compound 4, half-maximal inhibitory concentration: 29500 nM
The estimate for compound 4 lay 1.0-fold (0.01 log units) above the measured number, and the stated range covers the measured number.
By their numbers in this assay, from the lowest: compounds 2 and 1 (each within the scatter of the next); then compound 4; then compound 3.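

In this assay, methoxy recovers only part of what dimethylamino costs at this aromatic carbon (a 5.3-fold lower number from compound 3 to compound 4 (0.72 log units; beyond the scatter)), yet compound 4 remains apart from both the hydrogen compound (a 3.1-fold higher number from compound 1 to compound 4 (0.49 log units; beyond the scatter)) and the chloro compound (a 3.2-fold higher number from compound 2 to compound 4 (0.51 log units; beyond the scatter)). The earlier compounds shown here showed only two levels, with hydrogen and chloro inseparable and dimethylamino far from both, whereas methoxy now adds a level between them, so changes at this carbon need not produce either no shift or a large one. No information is available on what lies behind this order of the four groups.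

The compounds shown leave open whether any group at this carbon can give a number clearly lower than those of compound 1 and compound 2, for example a trifluoromethyl group, a nitrile or a carboxylic acid. They also leave open where a free hydroxyl or a primary amine would fall relative to methoxy and dimethylamino, and whether a longer ether chain such as ethoxy would stay close to methoxy.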